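This account rests on a few compounds, and the source may have more. Where it says the series, first, only, none or still open, it means among the compounds named here.

Working notes on the series. Compound 1 (`O=C(CN1CCN(c2nnc(Cc3ccccc3)c3ccccc23)CC1)Nc1c(F)cccc1F`) gives 84500 nM in a functional assay on A549 cells (Homo sapiens) for cytotoxicity, read by MTT assay, with a stated time of 72 h (a lower number here means a stronger inhibitor, a higher number a weaker inhibitor), and sits within the scatter of compound 2 (`Cc1ccc(NC(=O)CN2CCN(c3nnc(Cc4ccncc4)c4ccccc34)CC2)c(C)c1`), which gives 45000 nM in this assay as well. Within the data shown here, the two numbers therefore set no order, and the series so far offers no measured step that changes one place only.

Compound 3 (`O=C(CN1CCN(c2nnc(Cc3ccccc3)c3ccccc23)CC1)Nc1ccc(F)c(C(F)(F)F)c1`) has not yet been measured. It carries 4-fluoro-3-(trifluoromethyl)phenyl in place of 2,6-difluorophenyl on an amide-type nitrogen. The core of compound 1 stays as it is. Among the measured compounds shown here, with no measured step to draw on, the size of the change in this assay can only be estimated, and a modest move towards a lower number is expected, with no change beyond the scatter remaining a real possibility. The expected step (a 2.1-fold lower number from compound 1 to compound 3 (0.32 log units; beyond the scatter)) is kept small, as compound 2 at 45000 nM gives no sign of a much lower range in this series. For compound 3 the estimated value is 40000 nM with an expected range of 12000 nM to 100000 nM in this assay as the working figure.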

Compound 3, half-maximal inhibitory concentration: 2480 nM
The estimate for compound 3 lay 16-fold (1.21 log units) above the measured number; measured number outside the range, below it.
By their numbers in this assay, from the lowest: compound 3; then compounds 2 and 1 (each within the scatter of the next).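

Among these compounds, the aryl group on the amide-type nitrogen gives the first single-place step, and it is large: 4-fluoro-3-(trifluoromethyl)phenyl in place of 2,6-difluorophenyl gives a 34-fold lower number from compound 1 to compound 3 (1.53 log units; beyond the scatter) in this assay, with the core of compound 1 unchanged. This position therefore responds strongly to which substituted phenyl it carries, even though the leaving and entering groups are each one six-membered aromatic ring of carbon only, with no hydrogen-bond donors, no hydrogen-bond acceptors and no net charge. No measurement at hand bears on why the step is this large.

Going by these compounds, the change removes the 2,6-difluoro pattern and brings in the 4-fluoro and 3-trifluoromethyl groups in a single step, so the share of each in the step stays open. Unsubstituted phenyl, 4-fluorophenyl and 3-(trifluoromethyl)phenyl on the same nitrogen would separate these contributions, and whether a similar step holds with a pyridin-4-ylmethyl group in place of the benzyl group on the shared core also remains open.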